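The source may hold more compounds than are shown below. What is called first, only, known or untested is meant among the compounds shown, and "the series" means these compounds.

In a functional assay for inhibition, with Rattus norvegicus as the target (on this read-out higher numbers stand for weaker inhibition and lower numbers for stronger inhibition), compound 1 (`COc1c(-c2ccccc2)c(-c2ccccc2)c(OC(C)=O)c2ccccc12`) gives 11000 nM, compound 2 (`CCOC(=O)c1c(-c2ccccc2)c(OC(C)=O)c2ccccc2c1OC`) gives 5810 nM, and compound 3 (`CCCCc1c(CCCC)c(OC(C)=O)c2ccccc2c1OC`) gives 6020 nM. Compound 3 thus lies within the scatter of both other compounds. Compound 4 (`CCCCc1c(C)c(OC)c2ccccc2c1OC(C)=O`) differs from it by hydrogen in place of propyl on a saturated chain carbon bound to an aromatic carbon, which reads as butyl to methyl. Within the data shown here, no measured step covers this change directly. Among the measured compounds shown here, the only measured step, a 1.9-fold lower number from compound 1 to compound 2 (0.28 log units; within the scatter), exchanges phenyl for ethoxycarbonyl on an aromatic carbon, and it bears only loosely on the new change. With so little to go on, no step beyond the scatter is expected in this assay. The expected step is a 1.1-fold higher number from compound 3 to compound 4 (0.03 log units; within the scatter). For compound 4 the estimated value is 6500 nM, with an expected range of 3000 nM to 14000 nM.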

Compound 4, half-maximal inhibitory concentration: 200 nM
Estimate against measurement, compound 4: 33-fold (1.51 log units) above; the whole stated range lies above it.
By their numbers in this assay, from the lowest: compound 4; then compounds 2, 3 and 1 (each within the scatter of the next).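

Among these compounds, the step of a 30-fold lower number from compound 3 to compound 4 (1.48 log units; beyond the scatter) in this assay is the first here to go beyond the scatter. Among the compounds shown here, it shows that the group on this saturated chain carbon bound to an aromatic carbon matters greatly, as replacing butyl with methyl strengthens inhibition sharply, whereas the earlier compounds showed no clear difference. No evidence is available to explain this change. The compounds shown leave open whether an ethyl chain in this place would give a number nearer that of compound 3 or compound 4. They also leave open how an amine or a carboxylic acid on this chain would read.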